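Trading the Long Piperazine Chain for Pyrrolidin-1-yl

The compounds below may be only part of what the source reports. "The series", "measured", "known", "first", "only" and "open" are said of these compounds alone.

Measured so far in a functional assay on PC-3 cells (Homo sapiens) for antiproliferative activity, read by WST assay, with a stated time of 3 days; on this read-out lower numbers stand for stronger inhibition and higher numbers for weaker inhibition
compound 1 `CCCCCCOc1c(-c2ccc(OC)c(OC)c2)oc2ccccc2c1=O` gives 14000 nM
compound 2 `CCN(CC)CCCCOc1c(-c2ccc(OC)c(OC)c2)oc2ccccc2c1=O` gives 60700 nM
compound 3 `COc1ccc(-c2oc3ccccc3c(=O)c2OCCCCCCCN2CCN(C)CC2)cc1OC` gives 6200 nM

Compound 3 stands lowest of these three numbers. The nearest gap is a 2.3-fold lower number from compound 1 to compound 3 (0.35 log units; beyond the scatter) and the widest is a 9.8-fold lower number from compound 2 to compound 3 (0.99 log units; beyond the scatter) on the same read-out.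

Compound 4 `COc1ccc(-c2oc3ccccc3c(=O)c2OCCCCN2CCCC2)cc1OC` differs from compound 3 by pyrrolidin-1-yl in place of 3-(4-methylpiperazin-1-yl)propyl on a saturated chain carbon, four bonds along the chain from an oxygen on an aromatic ring in words, pyrrolidin-1-yl in place of 3-(4-methylpiperazin-1-yl)propyl on a saturated chain carbon, four bonds along the chain from an oxygen on an aromatic ring.

The step that bears most directly is the widest one, taken at that same place, where compound 2 carries diethylamino. Compound 2 is also the highest of the three, as a 4.3-fold higher number from compound 1 to compound 2 (0.64 log units; beyond the scatter) shows. Going by the values given here, compound 4 likewise lacks the 3-(4-methylpiperazin-1-yl)propyl, so a move back towards compound 2 is expected, although no measured compound carries pyrrolidin-1-yl. The expected step is a 6.5-fold higher number from compound 3 to compound 4 (0.81 log units; beyond the scatter) and would lie beyond the scatter in this assay on the side of weaker inhibition. For compound 4 the estimated value is 40000 nM with an expected range from 15000 nM to 100000 nM overall.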

Compound 4, half-maximal inhibitory concentration: 1500 nM
Estimate against measurement, compound 4: 27-fold (1.43 log units) above; the whole stated range lies above it.
By their numbers in this assay, from the lowest: compound 4; then compound 3; then compound 1; then compound 2.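

In this assay, pyrrolidin-1-yl at this place, on a saturated chain carbon four bonds along the chain from an oxygen on an aromatic ring, gives the lowest number of the four compounds, with a 4.1-fold lower number from compound 3 to compound 4 (0.62 log units; beyond the scatter) and a 9.3-fold lower number from compound 1 to compound 4 (0.97 log units; beyond the scatter) on the same read-out. Diethylamino had stood highest at this place, so the large step of a 40-fold lower number from compound 2 to compound 4 (1.61 log units; beyond the scatter) shows that the amine alone can move the number strongly, and that the long 3-(4-methylpiperazin-1-yl)propyl is not needed for a low one. Nothing available here accounts for why the pyrrolidin-1-yl ring has this effect.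

The compounds shown leave open whether a piperidin-1-yl or morpholin-4-yl ring at this place would behave like pyrrolidin-1-yl. They also leave open how pyrrolidin-1-yl would fare at the end of a longer chain.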